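The compounds below may be only part of what the source reports. "The series", "measured", "known", "first", "only" and "open" are said of these compounds alone.

Within the data shown here, in a functional assay on ACHN cells (Homo sapiens) for antiproliferative activity, read by sulforhodamine B assay (on this read-out higher numbers stand for weaker inhibition of growth and lower numbers for stronger inhibition of growth), compound 1 `CC(C)CCCOc1cccc(O)c1C(=O)/C=C/c1ccc(O)cc1` gives 3630 nM as the only true number so far. Compound 2 `COc1cccc(OCCC(C)(C)C)c1C(=O)/C=C/c1ccc(O)cc1` shows only a limit of > 30000 nM and no number. Compound 3 `CC(C)=CCOc1cccc(O)c1C(=O)/C=C/c1ccc(O)cc1` carries 2-methylprop-1-en-1-yl in place of isopentyl on a saturated chain carbon bound to an oxygen on an aromatic ring. Among the measured compounds shown here, no measured pair shows this change, so compound 1 at 3630 nM is the only anchor. The expected move is a 1.1-fold higher number from compound 1 to compound 3 (0.04 log units; within the scatter) and so nothing beyond the usual scatter, with no direction favoured. For compound 3 the expected value is 4000 nM (range 1200 nM to 15000 nM).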

Compound 3, concentration for 50% growth inhibition: > 30000 nM
Compound 3: a limit, no number; the forecaster's own chance of this, stated with the estimate: 10%; middle value at least 7.5-fold (0.87 log units) away from the limit.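

The chain on this oxygen turns out to be sensitive to a small edit: in this assay, 2-methylprop-1-en-1-yl in place of isopentyl brings an at least 8.2-fold higher number from compound 1 to compound 3 (0.91 log units; beyond the scatter). Compound 3 reads as a limit and not a number, so the full size of this loss of growth inhibition stays unknown: the limit of > 30000 nM in this assay, at which 2 of the 3 values shown sit.

The double bond and the shorter chain change together here, so the compounds shown do not separate their shares in the loss. From the compounds shown here alone, how an amine or a carboxylic acid at the end of this chain would behave also stays open.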